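The source may hold more compounds than are shown below. What is called first, only, known or untested is meant among the compounds shown, and "the series" means these compounds.

Compound 1 `CN(C)CCNc1nc(F)c(-c2nn(Cc3ccc(C#N)cc3)c(=O)c3ccccc23)cc1Cl`: 9760 nM
Compound 2 `N#Cc1ccc(Cn2nc(-c3cc(Cl)c(NCCC(=O)O)nc3F)c3ccccc3c2=O)cc1`: > 100000 nM

The measurements come from an ADME assay on HepG2 2.2.15 cells (Homo sapiens) for cytotoxicity, read by MTT assay, with a stated time of 8 days; a lower number here means that less compound is tolerated, a higher number that more compound is tolerated. Compound 2 reads > 100000 nM, which is a limit of the assay and not a number. Compound 2 thus stands at the limit of > 100000 nM in this assay, at which 1 of the 2 values shown sits.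

Compound 3 `N#Cc1ccc(Cn2nc(-c3cc(Cl)c(NCC(O)CO)nc3F)c3ccccc3c2=O)cc1` carries 1,2-dihydroxyethyl in place of the carboxymethyl of compound 2, on a saturated chain carbon bound to a nitrogen on an aromatic ring: 1,2-dihydroxyethyl in place of carboxymethyl on a saturated chain carbon bound to a nitrogen on an aromatic ring.

For the measured compounds named here, only one measured step bears on this change. It is large: an at least 10-fold higher number from compound 1 to compound 2 (1.01 log units; beyond the scatter). It swaps dimethylamino for carboxy at the end of the same chain, and compound 3, like compound 2, has no dimethylamino. A return to the level of compound 1 is therefore not expected, only a modest move to a lower number, if any. The expected change is an at least 1.4-fold lower number from compound 2 to compound 3 (0.15 log units; that floor lies within the scatter). For compound 3 the estimate is 70000 nM, with an expected range of 25000 nM to 100000 nM.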

Compound 3, half-maximal cytotoxic concentration: > 100000 nM
Compound 3: no number, only a limit (the forecaster's own chance of this, stated with the estimate: 50%); at least 1.4-fold (0.15 log units) between middle value and limit.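

In this assay compound 3 gives > 100000 nM, which is a limit of the assay and not a number. Against the dimethylamino end of compound 1, the 1,2-dihydroxyethyl end gives an at least 10-fold higher number from compound 1 to compound 3 (1.01 log units; beyond the scatter), so the large step seen earlier with carboxy is not confined to that one group. Compound 2 and compound 3 cannot be ordered, and the step between them cannot be read: the limit of > 100000 nM in this assay, at which 2 of the 3 values shown sit.

The compounds shown leave open how far this chain end can change before the number falls back toward the 9760 nM of compound 1. A primary amine, a single hydroxyl or a longer chain ending in dimethylamino at this place would show whether the dimethylamino group itself goes with the lower number, which the present compounds cannot tell.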